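The source may report more compounds than this note shows. Statements on the series, on what has been measured and on what is new or still open speak of the compounds shown alone.

Measured in a functional assay on HeLa cells (Homo sapiens) for antiproliferative activity, read by CCK-8 assay, with a stated time of 48 h; on this read-out lower numbers stand for stronger inhibition and higher numbers for weaker inhibition:
- compound 1 `O=C(CCCCCCOc1ccc(-c2nnc(-c3ccccc3)s2)cc1)NO`: > 50000 nM is a limit of the assay, not a number
- compound 2 `O=C(CCCCOc1cccc(-c2nnc(-c3ccccc3)s2)c1)NO` gives 1900 nM here
- compound 3 `O=C(CCCCCOc1cccc(-c2nnc(-c3ccccc3)s2)c1)NO` gives 780 nM here

Of the two true numbers, compound 3 holds the lower one (780 nM). Compound 4 `O=C(CCCCCCOc1cccc(-c2nnc(-c3ccccc3)s2)c1)NO` differs from compound 3 in one place (hydroxycarbamoyl)methyl in place of hydroxycarbamoyl on a saturated chain carbon, five bonds along the chain from an oxygen on an aromatic ring. For the measured compounds named here, the same swap, four bonds along the chain, is the only measured guide: a 2.4-fold lower number from compound 2 to compound 3 (0.39 log units; beyond the scatter) and that step was modest. A single step sets no firm trend, so only a similar modest drop in this assay is expected. For compound 4 the estimated value is 400 nM with an expected range of 130 nM to 1200 nM in this estimate. The expected change is a 2.0-fold lower number from compound 3 to compound 4 (0.29 log units; within the scatter) and it remains uncertain.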

Compound 4, half-maximal inhibitory concentration: 4900 nM
The estimate for compound 4 lay 12-fold (1.09 log units) below the measured number, and the stated range ends below it.
By their numbers in this assay, from the lowest: compound 3; then compound 2; then compound 4. At a limit, above all of these: compound 1.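

In this assay, adding to the chain stops paying here: the swap that lowered the number one bond earlier now gives a 6.3-fold higher number from compound 3 to compound 4 (0.80 log units; beyond the scatter) and so reverses direction. The longer chain also loses to the shorter one, with a 2.6-fold higher number from compound 2 to compound 4 (0.41 log units; beyond the scatter) as the result. Across compounds 2, 3 and 4, which differ only in chain length, the number falls and then rises, with compound 3 lowest of the three.

Nothing measured here gives a reason for this turn. Going by these compounds, whether a carboxylic acid or an amine in place of hydroxycarbamoyl, on the chain of compound 3, would keep or lose activity remains open.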